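Swapping the Aryl Group on the Sulfonyl: Cytotoxicity

The source may report more compounds than this note shows. Statements on the series, on what has been measured and on what is new or still open speak of the compounds shown alone.

Compound 1 `COc1ccc(S(=O)(=O)Nc2ccc(-c3nc4ccccc4o3)cc2)cc1` — in an ADME assay on HEK293 cells (Homo sapiens) for cytotoxicity, read by resazurin assay, with a stated time of 48 h (on this read-out lower numbers stand for higher toxicity in this test and higher numbers for lower toxicity in this test), compound 1 gives > 100000 nM, which is a limit of the test rather than a number.
Compound 2 `Cc1ccccc1S(=O)(=O)Nc1ccc2oc(-c3ccccc3)nc2c1` — in this assay compound 2 gives 57000 nM.

Compound 2 thus holds the only numerical result shown; the other entry, (the limit of > 100000 nM in this assay, at which 1 of the 2 values shown sits), is a limit. Compound 3 `COc1cccc(S(=O)(=O)Nc2ccc3oc(-c4ccccc4)nc3c2)c1` carries 3-methoxyphenyl in place of 2-methylphenyl on a sulfonyl sulfur. Among the measured compounds shown here, no two measured compounds differ in just one place, so no measured step guides this change. Both measured compounds show low toxicity, and the step of a 1.2-fold higher number from compound 2 to compound 3 (0.09 log units; within the scatter) is expected to stay within the usual scatter. Compound 3 is estimated at 70000 nM, between 30000 nM and 150000 nM.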

Compound 3, half-maximal cytotoxic concentration: 63000 nM
The estimate for compound 3 lay 1.1-fold (0.05 log units) above the measured number; measured number inside the range.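

The swap gives a 1.1-fold higher number from compound 2 to compound 3 (0.04 log units; within the scatter) in this assay, the first step measured at this place on the sulfonyl sulfur. So, in this pair, 3-methoxyphenyl, with its oxygen and its hydrogen-bond acceptor, and 2-methylphenyl cannot be told apart in this test. Compound 1 gives only a limit and differs from the others in more than one place, so it adds no step here: the limit of > 100000 nM in this assay, at which 1 of the 3 values shown sits.

Only these two aryl groups can be compared at this place. As far as these compounds go, whether a carboxylic acid or an amine on the aryl ring would change the number remains open.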